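Shortening the Amide Side Chain to an Amine

This account rests on a few compounds, and the source may have more. Where it says the series, first, only, none or still open, it means among the compounds named here.

Measured compounds in an assay on HEK293 cells for agonist activity at Toll-like receptor 2 (Homo sapiens); a lower number here means that less compound is needed, a higher number that more compound is needed for the effect:
compound 1 `CCCCCCCCCCCC(=O)OC[C@H](CSC[C@@H](N)C(=O)NCCCC(C)(C)CO)OC(=O)CCCCCCCCCCC` gives 30700 nM;
compound 2 `CCCCCCCCCCCC(=O)OC[C@H](CSC[C@@H](N)C(=O)NC(C)CCc1ccccc1)OC(=O)CCCCCCCCCCC` gives 160 nM;
compound 3 `CCCCCCCCCCCC(=O)OC[C@H](CSC[C@@H](N)C(=O)NCCCCCCCCCC(=O)O)OC(=O)CCCCCCCCCCC` gives 4400 nM.

Compound 3 stands second highest of the three numbers. Its nearest neighbour is compound 1, seen in a 7.0-fold lower number from compound 1 to compound 3 (0.84 log units; beyond the scatter); its furthest is compound 2, seen in a 28-fold higher number from compound 2 to compound 3 (1.44 log units; beyond the scatter). The unmeasured compound 4 `CCCCCCCCCCCC(=O)OC[C@H](CSC[C@@H](N)C(=O)NCCCCN)OC(=O)CCCCCCCCCCC` differs from compound 3 in one place: amino in place of 5-carboxypentyl on a saturated chain carbon, four bonds along the chain from an amide-type nitrogen. Among the measured compounds shown here, no measured step exchanges a carboxylic acid chain end for an amine, so none bears on this change directly. The closest comparison is a 7.0-fold lower number from compound 1 to compound 3 (0.84 log units; beyond the scatter), which likewise exchanged one chain end for another and moved the number modestly, whereas a 190-fold lower number from compound 1 to compound 2 (2.28 log units; beyond the scatter) shows how far a phenyl-bearing end moved it. Since compound 4 keeps a chain end of the same kind as compound 3 rather than a phenyl group, a step in this assay of modest size at most is expected, with uncertain direction. Compound 4 is estimated at 3000 nM, within 500 nM to 20000 nM, which is expected to mean a 1.5-fold lower number from compound 3 to compound 4 (0.17 log units; within the scatter).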

Compound 4, half-maximal effective concentration: 1040 nM
For compound 4 the middle estimate is 2.9-fold (0.46 log units) above the measured one; low and high end bracket the measured number.
By their numbers in this assay, from the lowest: compound 2; then compound 4; then compound 3; then compound 1.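

In this assay, amino in place of 5-carboxypentyl gives a 4.2-fold lower number from compound 3 to compound 4 (0.63 log units; beyond the scatter), so at this place on the chain the 4-aminobutyl end needs less compound than the 9-carboxynonyl end, by a step beyond the scatter. The same 4-aminobutyl end also stands far below the 4-(hydroxymethyl)-4-methylpentyl end, with a 30-fold lower number from compound 1 to compound 4 (1.47 log units; beyond the scatter), yet it does not reach the 1-methyl-3-phenylpropyl end, with a 6.5-fold higher number from compound 2 to compound 4 (0.81 log units; beyond the scatter). No measurement at hand accounts for these steps.

Going by these compounds, whether the step follows the amino group or the shorter chain stays open: a longer chain ending in an amine, or a short chain ending in a carboxylic acid, would separate the two. Also open, on these data alone, is what a phenyl ring would do on a chain that ends in an amine.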